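Benzyl group variation in a bis(trifluoromethyl)sulfonamide diamine series

The source may hold more compounds than are shown below. What is called first, only, known or untested is meant among the compounds shown, and "the series" means these compounds.

Measured so far:
Compound 1 `CC(C)(C)c1ccc(CNCCCNS(=O)(=O)c2cc(C(F)(F)F)cc(C(F)(F)F)c2)cc1` — in a functional assay on HT-29 cells (Homo sapiens) for inhibition, read by MTT assay, with a stated time of 72 h (a higher number here means a weaker inhibitor of growth, a lower number a stronger inhibitor of growth), compound 1 gives 2000 nM.
Compound 2 `COc1ccc(CNCCCNS(=O)(=O)c2cc(C(F)(F)F)cc(C(F)(F)F)c2)cc1OC` — in this assay compound 2 gives 2700 nM.
Compound 3 `O=S(=O)(NCCCNCc1ccc(Cl)c(C(F)(F)F)c1)c1cc(C(F)(F)F)cc(C(F)(F)F)c1` — in this assay compound 3 gives 11000 nM.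

Compound 3 stands at the highest number of the three in this assay. The shifts onto its aryl group, a 5.5-fold higher number from compound 1 to compound 3 (0.74 log units; beyond the scatter) and a 4.1-fold higher number from compound 2 to compound 3 (0.61 log units; beyond the scatter), are both modest and beyond the scatter, whereas a 1.4-fold higher number from compound 1 to compound 2 (0.13 log units; within the scatter) lies within it, so the two other aryl groups cannot be separated from one another on these numbers.

Compound 4 `O=S(=O)(NCCCNCc1ccc(C(F)(F)F)cc1)c1cc(C(F)(F)F)cc(C(F)(F)F)c1` differs from compound 3 in one place: 4-(trifluoromethyl)phenyl in place of 4-chloro-3-(trifluoromethyl)phenyl on a saturated chain carbon bound to an amine nitrogen. Among the measured compounds shown here, no measured pair removes the chlorine from this aryl group while keeping the trifluoromethyl, so the only steps that bear on the change are the two that arrive at compound 3, and both point the same way: every departure from its aryl group among the measured compounds has given a lower number. A step back toward the numbers of compound 1 and compound 2 is therefore the expectation, of modest size at most and possibly no larger than the scatter.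

For compound 4 in this assay the estimate is 6000 nM, with a range from 2500 nM to 14000 nM, which is expected to mean a 1.8-fold lower number from compound 3 to compound 4 (0.26 log units; within the scatter).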

Compound 4, concentration for 50% growth inhibition: 2900 nM
The estimate for compound 4 lay 2.1-fold (0.32 log units) above the measured number; measured number inside the range.
By their numbers in this assay, from the lowest: compounds 1, 2 and 4 (each within the scatter of the next); then compound 3.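

Notes on the aryl group on a saturated chain carbon bound to an amine nitrogen: in this assay, the change from 4-chloro-3-(trifluoromethyl)phenyl to 4-(trifluoromethyl)phenyl gives a 3.8-fold lower number from compound 3 to compound 4 (0.58 log units; beyond the scatter), the first measured step at this position that starts from the aryl group of compound 3. The other two new steps, a 1.1-fold higher number from compound 2 to compound 4 (0.03 log units; within the scatter) and a 1.5-fold higher number from compound 1 to compound 4 (0.16 log units; within the scatter), both lie within the scatter, so 4-(trifluoromethyl)phenyl cannot be separated from 3,4-dimethoxyphenyl or 4-(tert-butyl)phenyl, and among these four compounds only compound 3 stands apart. A trifluoromethyl on the ring therefore does not by itself go with the higher number, since compound 4 carries one too, and no measurement at hand accounts for the step.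

The step changes the substitution of the ring in more than one way, so 4-chlorophenyl and 3-(trifluoromethyl)phenyl would be needed to tell whether the chlorine, the trifluoromethyl placement or their combination sets compound 3 apart. Also open, going by these compounds, is whether the flat picture among compound 1, compound 2 and compound 4 holds with a longer chain in the shared core or with a pyridine ring in place of the benzene ring of the benzyl group.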